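A Methoxycarbonyl Group Added to Compound 1

The source may report more compounds than this note shows. Statements on the series, on what has been measured and on what is new or still open speak of the compounds shown alone.

In a physicochemical assay for solubility, using the shake flask method, measured as thermodynamic solubility, with a stated time of 2 h, at pH 6.5 (a lower number here means a less soluble compound, a higher number a more soluble compound), compound 1 `OC[C@H]1O[C@H](Oc2ccc(-n3ccc4ccccc43)cc2Cl)[C@@H](O)[C@@H](O)[C@@H]1O` gives 31.5 ug/mL, the lower of the two true numbers, while compound 3 `OC[C@H]1O[C@H](Oc2ccc(-n3ccc4ccccc43)cc2F)[C@@H](O)[C@@H](O)[C@@H]1O` gives 67 ug/mL. Compound 2 `OC[C@H]1O[C@H](Oc2ccc(-n3ccc4c(OCc5ccccc5)cccc43)cc2Cl)[C@@H](O)[C@@H](O)[C@@H]1O` reaches only a limit, < 0.1 ug/mL. Compound 4 `COC(=O)c1ccc2c(ccn2-c2ccc(O[C@H]3O[C@H](CO)[C@@H](O)[C@H](O)[C@@H]3O)c(Cl)c2)c1` differs from compound 1 by methoxycarbonyl in place of hydrogen on an aromatic carbon. The closest guide is benzyloxy in place of hydrogen on an aromatic carbon, an at least 310-fold lower number from compound 1 to compound 2 (2.49 log units; beyond the scatter). Fluoro in place of chloro, a 2.1-fold higher number from compound 1 to compound 3 (0.33 log units; beyond the scatter), is a modest step and a different kind of change. A lower number is therefore expected, though a less extreme drop, an estimated 5.3-fold lower number from compound 1 to compound 4 (0.72 log units; beyond the scatter). Compound 4 is estimated at 6 ug/mL, with an expected range of 1 ug/mL to 25 ug/mL.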

Compound 4, solubility: 2.1 ug/mL
The estimate for compound 4 lay 2.9-fold (0.46 log units) above the measured number; the range from low to high includes it.
By their numbers in this assay, from the lowest: compound 4; then compound 1; then compound 3. At a limit, below all of these: compound 2.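

In this assay, methoxycarbonyl in place of hydrogen on this aromatic carbon gives a 15-fold lower number from compound 1 to compound 4 (1.18 log units; beyond the scatter) and so a group of 4 heavy atoms with no ring is enough for a large step. Compound 2, with benzyloxy, stands only at a limit: the limit of < 0.1 ug/mL in this assay, at which 1 of the 4 values shown sits. Compound 4 gives a true number, so a step down from compound 1 by adding a group to the fused system now has a measured size.

On these data alone, whether a carboxylic acid or an amine on the same carbon would also lower the number remains open. So does whether the step would keep its size with fluoro in place of chloro.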